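Extending the propyl chain on the bromo compound

The compounds below may be only part of what the source reports. "The series", "measured", "known", "first", "only" and "open" are said of these compounds alone.

- compound 1 `CCCOc1ccccc1-c1nc2c(cnn2-c2ccccc2)c(=O)[nH]1`: 234 nM
- compound 2 `CCCOc1ccccc1-c1nc2c(cnn2-c2ccc(Br)cc2)c(=O)[nH]1`: 830 nM

In a functional assay on corpus cavernosum (Rattus norvegicus) for activation (a higher number here means that more compound is needed for the effect, a lower number that less compound is needed), compound 2 holds the higher of the two numbers at 830 nM. Compound 3 `CCCCOc1ccccc1-c1nc2c(cnn2-c2ccc(Br)cc2)c(=O)[nH]1` is still to be measured. It differs from compound 2 by methyl in place of hydrogen on a saturated chain carbon, three bonds along the chain from an oxygen on an aromatic ring, which reads as propyl to butyl. Among the measured compounds shown here, the only measured step, a 3.5-fold higher number from compound 1 to compound 2 (0.55 log units; beyond the scatter), is bromo in place of hydrogen on an aromatic carbon. It is a modest step at a different place and says little about the chain. For the measured compounds named here, no measured step varies the chain, so no direction can be argued, and a shift within the scatter in this assay is the working expectation. The estimated step is a 1.1-fold lower number from compound 2 to compound 3 (0.04 log units; within the scatter). For compound 3, the expected value is 750 nM, with an estimated range of 280 nM to 2000 nM.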

Compound 3, half-maximal effective concentration: 4.89 nM
Estimate against measurement, compound 3: 150-fold (2.19 log units) above, outside the stated range (below it).
By their numbers in this assay, from the lowest: compound 3; then compound 1; then compound 2.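

In this assay, propyl to butyl on the bromo compound gives a 170-fold lower number from compound 2 to compound 3 (2.23 log units; beyond the scatter), so this saturated chain carbon, three bonds along the chain from an oxygen on an aromatic ring, is a place where a single added methyl can change the number greatly. The earlier pair showed only a 3.5-fold higher number from compound 1 to compound 2 (0.55 log units; beyond the scatter), a modest step for bromo in place of hydrogen on an aromatic carbon, and gave no reading of the chain. Nothing at hand accounts for the size of the new step.

On these data alone, whether the drop continues, holds or reverses with a longer chain such as pentyl, or with a chain ending in an amine, remains open. Also open, as far as these compounds go, is whether propyl to butyl gives a step of similar size with hydrogen in place of the bromo.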